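The source may report more compounds than this note shows. Statements on the series, on what has been measured and on what is new or still open speak of the compounds shown alone.

Compound 3 `COc1cc2c(Oc3ccc(NC(=O)c4nn(-c5ccc(F)cc5)c(=O)c5ccccc45)cc3F)ccnc2cc1OCCCN1CCC(C)CC1` holds the second highest of three numbers measured in a functional assay on NCI-H460 cells (Homo sapiens) for cytotoxicity, read by MTT assay, with a stated time of 72 h (a lower number here means a stronger inhibitor, a higher number a weaker inhibitor), where compound 3 gives 110 nM. Compound 1 `COc1cc2c(Oc3ccc(NC(=O)c4nn(-c5ccc(F)cc5)c(=O)c5ccccc45)cc3F)ccnc2cc1OCCCN1CCN(C)CC1` gives 91 nM, and the step of a 1.2-fold higher number from compound 1 to compound 3 (0.08 log units; within the scatter) shows that exchanging the amine at the chain end stays within the scatter. Compound 2 `COc1cc2c(Oc3ccc(NC(=O)c4nn(-c5ccc([N+](=O)[O-])cc5)c(=O)c5ccccc45)cc3F)ccnc2cc1OCCCN1CCCCC1` gives 1300 nM. Compound 4 `COc1cc2c(Oc3ccc(NC(=O)c4nn(-c5ccc([N+](=O)[O-])cc5)c(=O)c5ccccc45)cc3F)ccnc2cc1OCCCN1CCC(C)CC1` is compound 3 with nitro in place of fluoro on an aromatic carbon. Among the compounds with values here, no measured step covers this exact change, but compound 4 differs only at the amine, where such exchanges stayed within the scatter, from the nitro-bearing compound 2, which gives 1300 nM. The expected step of an 11-fold higher number from compound 3 to compound 4 (1.04 log units; beyond the scatter) is therefore a clear rise in number. Compound 4 is estimated at 1200 nM, between 400 nM and 3500 nM.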

Compound 4, half-maximal inhibitory concentration: 1340 nM
Beside the measured number, compound 4's estimate is 1.1-fold (0.05 log units) below it, and the stated range covers the measured number.
By their numbers in this assay, from the lowest: compounds 1 and 3 (each within the scatter of the next); then compounds 2 and 4 (each within the scatter of the next).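

Within the data shown here, replacing 4-fluorophenyl with 4-nitrophenyl is the first single change here to move the number beyond the scatter (a 12-fold higher number from compound 3 to compound 4 (1.09 log units; beyond the scatter)). The methyl on the saturated ring does not move it beyond the scatter in the nitro pair (a 1.0-fold higher number from compound 2 to compound 4 (0.01 log units; within the scatter)), so among these compounds the group on this aromatic carbon counts for far more than the amine at the chain end. Nothing given here explains the rise. As far as these compounds go, whether chloro or methoxy at this position would give a number closer to that of fluoro or of nitro remains open. So does whether a morpholine at the chain end would stay within the scatter.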